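The source may hold more compounds than are shown below. What is called first, only, known or untested is meant among the compounds shown, and "the series" means these compounds.

Measured so far in an assay on L1.2 cells for binding affinity to C-C chemokine receptor type 8 (Homo sapiens); on this read-out lower numbers stand for stronger inhibition and higher numbers for weaker inhibition:
compound 1 `COCC(=O)N1CCC(NS(=O)(=O)c2ccc(NC(=O)c3ccccc3C)c3ccccc23)CC1`: 15.8 nM
compound 2 `Cc1ccccc1C(=O)Nc1ccc(S(=O)(=O)NC2CCN(C(=O)NC(C)C)CC2)c2ccccc12`: 77.7 nM

Among the compounds with values here, compound 2 has the higher of these two numbers; the only step to it is a 4.9-fold higher number from compound 1 to compound 2 (0.69 log units; beyond the scatter). Compound 3 `CCCC(=O)N1CCC(NS(=O)(=O)c2ccc(NC(=O)c3ccccc3C)c3ccccc23)C1` differs from compound 2 by 1-(propylcarbonyl)pyrrolidin-3-yl in place of 1-(isopropylcarbamoyl)piperidin-4-yl on a sulfonamide nitrogen. Within the data shown here, only the step from compound 1 to compound 2 bears on this change, and it was modest. As far as these compounds go, as compound 3 again carries a carbonyl on the ring nitrogen, as compound 1 does, a somewhat lower number is expected, but the five-membered ring is untested, so the range is wide. Compound 3 is estimated at 30 nM, between 8 nM and 120 nM, which would be a step of a 2.6-fold lower number from compound 2 to compound 3 (0.41 log units; beyond the scatter).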

Compound 3, inhibition constant: 34.3 nM
Beside the measured number, compound 3's estimate is 1.1-fold (0.06 log units) below it, and the stated range covers the measured number.
By their numbers in this assay, from the lowest: compound 1; then compound 3; then compound 2.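

In this assay, the 1-(propylcarbonyl)pyrrolidin-3-yl group on the sulfonamide nitrogen gives a 2.3-fold lower number from compound 2 to compound 3 (0.36 log units; beyond the scatter) and also a 2.2-fold higher number from compound 1 to compound 3 (0.34 log units; beyond the scatter) in a second comparison. The position therefore accepts a five-membered non-aromatic ring, with compound 3 lying between the two compounds carrying six-membered rings. No evidence is available to explain either step. As far as these compounds go, the ring and the group on its nitrogen change together in both steps, and the share of each stays open. Also open, from the compounds shown here alone, is what a 1-(propylcarbonyl)piperidin-4-yl group or a longer chain ending in a carboxylic acid would give.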